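Swapping chloro for benzyloxy on a bis-chalcone scaffold

The source may report more compounds than this note shows. Statements on the series, on what has been measured and on what is new or still open speak of the compounds shown alone.

Measured compounds:
- compound 1 `Cc1cc(O)c(C(=O)/C=C/c2ccccc2)c(-c2ccc(Cl)cc2)c1C(=O)/C=C/c1ccccc1`, in a functional assay on MDA-MB-231 cells (Homo sapiens) for cytotoxicity, read by MTT assay, with a stated time of 24 h (on this read-out higher numbers stand for weaker inhibition and lower numbers for stronger inhibition), compound 1 gives 4400 nM
- compound 2 `COc1ccc(/C=C/C(=O)c2c(C)cc(O)c(C(=O)/C=C/c3ccc(OC)c(OC)c3)c2-c2ccccc2)cc1OC`, in this assay compound 2 was reported as "not active" (no number reported)

Among the measured compounds shown here, compound 1 is the only member of this small set with a numerical value in this assay; compound 2 carries a different substitution pattern and was reported without a number, so no step between the two can be drawn from what they show.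

Compound 3 `Cc1cc(O)c(C(=O)/C=C/c2ccccc2)c(-c2ccc(OCc3ccccc3)cc2)c1C(=O)/C=C/c1ccccc1` differs from compound 1 in one place: benzyloxy in place of chloro on an aromatic carbon. For the measured compounds named here, with no measured pair available to anchor this change, the size of the step is open. Compound 1 sits at a modest level, and the expectation is that compound 3 lands near it, with a slight lean toward weaker inhibition and a real chance that only a limit is reported.

Compound 3 is therefore estimated at 6500 nM, within a range from 2000 nM to 22000 nM, which means an expected step of a 1.5-fold higher number from compound 1 to compound 3 (0.17 log units; within the scatter).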

Compound 3, half-maximal inhibitory concentration: "not active" (no number reported)
The entry for compound 3 holds no number, and the estimate cannot be compared.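

In this assay, among the compounds shown here, compound 3 was reported without a number, so no step from compound 1 to compound 3 can be read. The compounds shown leave open how far benzyloxy in place of chloro shifts the read-out. No measured evidence bears on this result.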